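This account rests on a few compounds, and the source may have more. Where it says the series, first, only, none or still open, it means among the compounds named here.

Within the data shown here, compound 2 `COC(=O)c1ccccc1C(=O)/C=C/c1ccccc1` stands at 1950 nM in a functional assay for inhibition, with Homo sapiens as the target (on this read-out higher numbers stand for weaker inhibition and lower numbers for stronger inhibition), with compound 1 `O=C(/C=C/c1ccccc1)c1ccccc1[N+](=O)[O-]`, which gives 1520 nM in this assay, the only other number so far. The step of a 1.3-fold higher number from compound 1 to compound 2 (0.11 log units; within the scatter) shows that exchanging one group on the aromatic carbon barely moved the read-out. Compound 3 `O=C(/C=C/c1ccccc1)c1ccccc1NS(=O)(=O)C(F)(F)F` carries the change (((trifluoromethyl)sulfonyl)amino in place of methoxycarbonyl on an aromatic carbon), a larger group with a hydrogen-bond donor. Among the measured compounds shown here, because the only comparable step is a 1.3-fold higher number from compound 1 to compound 2 (0.11 log units; within the scatter), the expected step of a 1.2-fold lower number from compound 2 to compound 3 (0.09 log units; within the scatter) is small, with no clear direction. Compound 3 is therefore estimated at 1600 nM, within a range from 500 nM to 5000 nM.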

Compound 3, half-maximal inhibitory concentration: 5850 nM
Estimate against measurement, compound 3: 3.7-fold (0.56 log units) below; the measured number lies above the stated range.
By their numbers in this assay, from the lowest: compounds 1 and 2 (each within the scatter of the next); then compound 3.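

In this assay the aromatic carbon ortho to a large group no longer looks indifferent to what it carries: ((trifluoromethyl)sulfonyl)amino gives a 3.0-fold higher number from compound 2 to compound 3 (0.48 log units; beyond the scatter) and a 3.8-fold higher number from compound 1 to compound 3 (0.59 log units; beyond the scatter) as its steps, a modest move towards weaker inhibition that the earlier nitro and methoxycarbonyl pair did not show. The new group is larger than methoxycarbonyl and brings a hydrogen-bond donor, but these two differences cannot be separated here. No measurement on hand explains the weaker inhibition.

As far as these compounds go, it remains open how a plain amine or a carboxylic acid would read on this carbon. From the compounds shown here alone, it also remains open whether a methylsulfonylamino group, which has no fluorine, would give the same weaker inhibition.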